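The compounds below may be only part of what the source reports. "The series", "measured", "known", "first", "only" and "open" are said of these compounds alone.

The measured compounds, all in the same shared core:

- compound 1 `CCCC(Oc1ccc(-n2cc(C(F)(F)F)c(C)n2)cc1)c1ccc(C(=O)NCCC(=O)O)cc1`, which in a functional assay on cells for antagonist activity at Glucagon receptor (Homo sapiens), read by cAMP accumulation, in the presence of a further agent that is not named here (a lower number here means a stronger inhibitor, a higher number a weaker inhibitor), gives 8300 nM
- compound 2 `CCCC(Oc1ccc(-n2cc(C#N)cn2)cc1)c1ccc(C(=O)NCCC(=O)O)cc1`, for which this assay reports only a limit, > 50000 nM
- compound 3 `CCCC(Oc1ccc(-n2cccn2)cc1)c1ccc(C(=O)NCCC(=O)O)cc1`, for which this assay reports only a limit, > 55000 nM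

Compound 3 therefore stands at a limit of this assay and no number is known for it; the same holds for compound 2, the other value sitting at a limit (the limit of > 55000 nM in this assay, at which 1 of the 3 values shown sits, (the limit of > 50000 nM in this assay, at which 1 of the 3 values shown sits)).

Compound 4 `CCCC(Oc1ccc(-n2cc(C)cn2)cc1)c1ccc(C(=O)NCCC(=O)O)cc1` differs from compound 3 by methyl in place of hydrogen on an aromatic carbon. Among the measured compounds shown here, only one step with a readable size touches compound 3: the step of an at least 6.6-fold higher number from compound 1 to compound 3 (0.82 log units; beyond the scatter), in which the group removed carried both a methyl and a trifluoromethyl. The step that the two limits leave unreadable from compound 2 to compound 3 gives no size, as both ends are limits. A single methyl restores only part of what compound 1 carries, so for compound 4 a small move toward a lower number is expected, estimated as an at least 1.5-fold lower number from compound 3 to compound 4 (0.19 log units; that floor lies within the scatter). Compound 4 is thus expected to give about 35000 nM in this assay, within a range of 10000 nM to 100000 nM, with a real chance that only a limit is again reported.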

Compound 4, antagonist equilibrium constant: 11000 nM
Compound 4: middle estimate off by 3.2-fold (0.50 log units), on the high side; low and high end bracket the measured number.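

Putting methyl in place of hydrogen on this carbon gives an at least 5.0-fold lower number from compound 3 to compound 4 (0.69 log units; beyond the scatter), so in this assay this single methyl alone is enough to bring a readable number. Methyl in place of cyano at the same carbon gives an at least 4.5-fold lower number from compound 2 to compound 4 (0.65 log units; beyond the scatter), so the methyl and the nitrile are not interchangeable here. With 4-methyl-1H-pyrazol-1-yl in place of 3-methyl-4-(trifluoromethyl)-1H-pyrazol-1-yl, the result is a 1.3-fold higher number from compound 1 to compound 4 (0.12 log units; within the scatter), so the larger group of compound 1 shows no readable advantage over the single methyl.

The true size of the step from hydrogen to methyl stays open, since compound 3 has only a limit and not a number: the limit of > 55000 nM in this assay, at which 1 of the 4 values shown sits.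

Also open, as far as these compounds go, is whether an ethyl group, a longer chain, an amine or a carboxylic acid on this carbon would hold the number of compound 4 or move it.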